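The source may hold more compounds than are shown below. What is called first, only, known or untested is meant among the compounds shown, and "the series" means these compounds.

Compound 1 `Cc1ccc(-c2cc(C(=O)N3CCC4(CC3)CC(=O)c3nn(C(C)(C)C)cc3O4)c3ccccc3n2)cc1` is the weakest of the three compounds measured in a functional assay on A549 cells (Homo sapiens) for inhibition, read by MTT assay, with a stated time of 72 h (a lower number here means a stronger inhibitor, a higher number a weaker inhibitor), where compound 1 gives 5300 nM. Its two analogues carry a nitrogen-bearing substituent in place of the methyl on the pendant ring: compound 2 `CC(C)(C)n1cc2c(n1)C(=O)CC1(CCN(C(=O)c3cc(-c4ccc(N)cc4)nc4ccccc34)CC1)O2` gives 970 nM and compound 3 `CN(C)c1ccc(-c2cc(C(=O)N3CCC4(CC3)CC(=O)c3nn(C(C)(C)C)cc3O4)c3ccccc3n2)cc1` gives 1150 nM. Both changes lowered the number, with a 5.5-fold lower number from compound 1 to compound 2 (0.74 log units; beyond the scatter) and a 4.6-fold lower number from compound 1 to compound 3 (0.66 log units; beyond the scatter), while the two substituted analogues sit close to one another, a 1.2-fold higher number from compound 2 to compound 3 (0.07 log units; within the scatter).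

Compound 4 `CC(C)(C)n1cc2c(n1)C(=O)CC1(CCN(C(=O)c3cc(-c4ccncc4)nc4ccccc34)CC1)O2` has not yet been measured in this assay. It differs from compound 1 by a single exchange of the pendant ring, (pyridin-4-yl in place of 4-methylphenyl on an aromatic carbon). Among the compounds with values here, no measured step involves a ring nitrogen, so the change is not directly covered; the nearest guides are the steps from compound 1 to compound 2 and to compound 3, both of which introduced a nitrogen on that ring and both modest in size. On this basis the number for compound 4 is expected to fall somewhat below that of compound 1, though with less confidence than for a repeat of a measured change. Compound 4 is therefore estimated at 2500 nM, within a range of 800 nM to 8000 nM. That estimate would mean an expected step of a 2.1-fold lower number from compound 1 to compound 4 (0.33 log units; beyond the scatter).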

Compound 4, half-maximal inhibitory concentration: 550 nM
The estimate for compound 4 lay 4.5-fold (0.66 log units) above the measured number, outside the stated range (below it).
By their numbers in this assay, from the lowest: compounds 4, 2 and 3 (each within the scatter of the next, the first and the last beyond it); then compound 1.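

In this assay the exchange of 4-methylphenyl for pyridin-4-yl gives a 9.6-fold lower number from compound 1 to compound 4 (0.98 log units; beyond the scatter) and shows that this position does not need an amino or dimethylamino substituent on a phenyl ring for the number to fall: a ring nitrogen with no substituent also lowers it. Set against the two substituted analogues, the result is split, with a 2.1-fold lower number from compound 3 to compound 4 (0.32 log units; beyond the scatter) and, in the other comparison, a 1.8-fold lower number from compound 2 to compound 4 (0.25 log units; within the scatter) so that compound 4 and compound 2 cannot be told apart here, while compound 1 stands apart from all three others. Nothing available here accounts for these differences at this position.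

The compounds shown leave open whether the step from compound 1 belongs to the entry of the ring nitrogen or to the loss of the methyl, a question that an unsubstituted phenyl at this position would address. They also leave open whether the place of the ring nitrogen matters, which pyridin-3-yl or pyridin-2-yl would test, and whether a second ring nitrogen, as in pyrimidin-5-yl, would move the number further.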